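From chloro to methoxy on a shared core

The source may hold more compounds than are shown below. What is called first, only, known or untested is meant among the compounds shown, and "the series" means these compounds.

In an ADME assay on HaCaT cells (Homo sapiens) for cytotoxicity, read by MTT assay, with a stated time of 48 h (a higher number here means a weaker inhibitor, a lower number a stronger inhibitor), compound 1 `Cc1cc2nc(-c3cn(-c4ccccc4)nc3-c3ccc(F)cc3)[nH]c2cc1C` gives > 50000 nM, which is a limit of the assay and not a number. Compound 2 `Cc1cc2nc(-c3cn(-c4ccccc4)nc3-c3ccc(Cl)cc3)[nH]c2cc1C` gives > 50000 nM, and this too is a limit rather than a number. Compound 2 therefore has no exact value to start from, and the evidence so far is the limit of > 50000 nM in this assay, at which 2 of the 2 values shown sit.

Compound 3 `COc1ccc(-c2nn(-c3ccccc3)cc2-c2nc3cc(C)c(C)cc3[nH]2)cc1` keeps the shared core and changes a single group: methoxy in place of chloro on an aromatic carbon. Here, methoxy takes the place of chloro on an aromatic carbon, para to a large group.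

Going by the values given here, only one measured step bears on this change, the swap of chloro in place of fluoro on an aromatic carbon, and it is a step that the two limits leave unreadable from compound 1 to compound 2. It offers no size to carry over and no direction to follow. Any expectation must therefore lean on the position of compound 2 at > 50000 nM, so no step beyond the scatter is expected in this assay.

The expected change is a step that the limit leaves unreadable from compound 2 to compound 3. Compound 3 is estimated at 60000 nM, with an expected range from 25000 nM to 150000 nM.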

Compound 3, half-maximal inhibitory concentration: 21400 nM
Estimate against measurement, compound 3: 2.8-fold (0.45 log units) above; the measured number lies below the stated range.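

The change from 4-chlorophenyl to 4-methoxyphenyl gives, in this assay, an at least 2.3-fold lower number from compound 2 to compound 3 (0.36 log units; beyond the scatter), and methoxy in place of fluoro at the same place gives an at least 2.3-fold lower number from compound 1 to compound 3 (0.36 log units; beyond the scatter). A lower number here means that less compound is needed for the effect on the cells, so this position is not silent: a single swap on this aromatic carbon can bring a compound of this series into the range where the assay returns a real number, which the fluoro and chloro compounds could not show. Each of these steps gives only a smallest size and the real steps may be larger, since both earlier compounds rest on a limit and not on a number: the limit of > 50000 nM in this assay, at which 2 of the 3 values shown sit.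

The steps involving limits stay open in their true size, and the step between fluoro and chloro still cannot be read, so nothing shown ranks those two groups against each other. As far as these compounds go, it also remains open whether the oxygen of methoxy or its added carbon goes with the lower number, a question that a hydroxyl, an amine or a longer chain such as ethoxy at this place would bear on.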